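Amide-nitrogen substituent changes on the shared quinolone core

The compounds below may be only part of what the source reports. "The series", "measured", "known", "first", "only" and "open" are said of these compounds alone.

Values in a functional assay on A549 cells (Homo sapiens) for cytotoxicity, read by MTT assay; a higher number here means a weaker inhibitor, a lower number a stronger inhibitor:
- compound 1 `CCn1cc(C(=O)Nc2ccccc2N)c(=O)c2cc(F)c(N3CCNC(C)C3)c(F)c21`: 5900 nM
- compound 2 `CCn1cc(C(=O)Nc2cc([N+](=O)[O-])ccc2F)c(=O)c2cc(F)c(N3CCNC(C)C3)c(F)c21`: 1700 nM
- compound 3 `CCn1cc(C(=O)NCc2ccc(OC)cc2)c(=O)c2cc(F)c(N3CCNC(C)C3)c(F)c21`: 7000 nM

Compound 1 stands second highest of the three numbers. Its nearest neighbour is compound 3 (a 1.2-fold higher number from compound 1 to compound 3 (0.07 log units; within the scatter)), its furthest compound 2 (a 3.5-fold lower number from compound 1 to compound 2 (0.54 log units; beyond the scatter)).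

Compound 4 `CCn1cc(C(=O)Nc2nccs2)c(=O)c2cc(F)c(N3CCNC(C)C3)c(F)c21` is not yet measured. It differs from compound 1 at one place only: 1,3-thiazol-2-yl in place of 2-aminophenyl on an amide-type nitrogen.

Two measured steps change the same amide-type nitrogen substituent. Going to 2-fluoro-5-nitrophenyl gave a 3.5-fold lower number from compound 1 to compound 2 (0.54 log units; beyond the scatter); going to 4-methoxybenzyl gave a 1.2-fold higher number from compound 1 to compound 3 (0.07 log units; within the scatter). One replacement moved the number beyond the scatter, one did not, and the two replaced groups differ from each other in direction as well. For the measured compounds named here, no measured compound carries a 1,3-thiazol-2-yl or any five-membered aromatic ring, so the direction for compound 4 cannot be read from the set.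

The expected step is therefore small, a 1.2-fold lower number from compound 1 to compound 4 (0.07 log units; within the scatter), with either direction possible. Compound 4 is estimated at 5000 nM in this assay, within 1800 nM to 14000 nM.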

Compound 4, half-maximal inhibitory concentration: 20200 nM
For compound 4 the middle estimate is 4.0-fold (0.61 log units) below the measured one; measured number above the stated range.
By their numbers in this assay, from the lowest: compound 2; then compounds 1 and 3 (each within the scatter of the next); then compound 4.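

For the compounds shown here, of the replacements on this amide-type nitrogen, 1,3-thiazol-2-yl is the only one that raises the number beyond the scatter relative to the 2-aminophenyl of compound 1 in this assay (a 3.4-fold higher number from compound 1 to compound 4 (0.53 log units; beyond the scatter)), and the rise also holds against the 4-methoxybenzyl group (a 2.9-fold higher number from compound 3 to compound 4 (0.46 log units; beyond the scatter)). Compound 4 is thus the weakest of the four, and the substituents on this nitrogen now span a large range rather than a modest one (a 12-fold higher number from compound 2 to compound 4 (1.07 log units; beyond the scatter)). Nothing available accounts for this shift.

Open, on these data alone, is whether the higher number goes with the five-membered ring, with its sulfur, or with the departure of the 2-aminophenyl group. An unsubstituted phenyl or a 1,3-oxazol-2-yl group on the same nitrogen would help separate these readings.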